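The source may hold more compounds than are shown below. What is called first, only, known or untested is meant among the compounds shown, and "the series" means these compounds.

Within the data shown here, in a functional assay on RS4-11 cells (Homo sapiens) for inhibition, read by CCK-8 assay, with a stated time of 48 h, tested at 20 uM (on this read-out lower numbers stand for less inhibition of growth and higher numbers for more inhibition of growth at the one concentration tested), compound 2 `COc1ccc(-c2nnc(NC(=O)/C(C#N)=C/c3cccc(OS(=O)(=O)c4ccc(C)cc4)c3)s2)cc1` gives 79%, the higher of the two numbers so far, while compound 1 `Cc1ccc(S(=O)(=O)Oc2cccc(/C=C(\C#N)C(=O)Nc3nnc(-c4ccccc4)s3)c2)cc1` gives 35%. Compound 3 `COc1ccccc1-c1nnc(NC(=O)/C(C#N)=C/c2cccc(OS(=O)(=O)c3ccc(C)cc3)c2)s1` has the same atoms joined differently: 2-methoxyphenyl in place of 4-methoxyphenyl on an aromatic carbon. Among the measured compounds shown here, the one measured step that bears on this is large, a number 44 percentage points higher from compound 1 to compound 2 (beyond the scatter), with methoxy in place of hydrogen on an aromatic carbon. For the measured compounds named here, no measured compound carries 2-methoxyphenyl, so only part of that gain is expected to remain. The expected change is a number 19 percentage points lower from compound 2 to compound 3 (beyond the scatter). In this assay, the estimated value for compound 3 is 60%, with an expected range from 35% to 85%.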

Compound 3, percent growth inhibition at one concentration: 41%
Compound 3: middle estimate off by 19 percentage points, on the high side; low and high end bracket the measured number.
By their numbers in this assay, from the lowest: compounds 1 and 3 (each within the scatter of the next); then compound 2.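

In this assay, methoxy does not have the same effect wherever it stands on the phenyl ring: 2-methoxyphenyl in place of 4-methoxyphenyl gives a number 38 percentage points lower from compound 2 to compound 3 (beyond the scatter). Methoxy in place of hydrogen, in the form of 2-methoxyphenyl, gives a number 6 percentage points higher from compound 1 to compound 3 (within the scatter), so among these compounds the large gain belongs to 4-methoxyphenyl alone. Nothing available explains the difference between the two arrangements. From the compounds shown here alone, it remains open whether the gain requires methoxy itself, or whether an ethoxy or dimethylamino group in its place on 4-methoxyphenyl would keep it.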